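This account rests on a few compounds, and the source may have more. Where it says the series, first, only, none or still open, it means among the compounds named here.

Measured so far:
- compound 1, `CCS(=O)(=O)Nc1cccc2c1CCC[C@H]2c1c[nH]cn1`: 170 nM in an assay on isolated protein for agonist activity at Alpha-1A adrenergic receptor (Oryctolagus cuniculus); a higher number here means that more compound is needed for the effect, a lower number that less compound is needed
- compound 2, `CC(C)S(=O)(=O)Nc1cccc2c1CCCC2c1c[nH]cn1`: 6760 nM in this assay

Compound 2 has the highest number of the two, and the gap to compound 1 is far beyond the usual scatter, so more of compound 2 is needed for the same effect. Compound 1 and compound 2 differ in more than one place at once, so nothing can be read from their pair about any single change; only the two values themselves are known.

The next compound is compound 3, `CC(=O)Nc1cccc2c1CCCC2c1c[nH]cn1`. It differs from compound 2 in one place: acetyl in place of isopropylsulfonyl on a nitrogen on an aromatic ring. Among the compounds with values here, with no measured pair showing this same change, the direction of the step cannot be taken from data. The expectation is a modest step toward a lower number, close to the edge of the scatter, estimated as a 2.3-fold lower number from compound 2 to compound 3 (0.35 log units; beyond the scatter). Compound 3 is therefore expected to come out near 3000 nM, with a range from 600 nM to 15000 nM.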

Compound 3, half-maximal effective concentration: 1290 nM
For compound 3 the middle estimate is 2.3-fold (0.37 log units) above the measured one, within the range that was stated.
By their numbers in this assay, from the lowest: compound 1; then compound 3; then compound 2.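

In this assay, within the data shown here, putting acetyl in place of isopropylsulfonyl on the nitrogen gives a 5.2-fold lower number from compound 2 to compound 3 (0.72 log units; beyond the scatter), the first single change in this set that can be read on its own. It shows that the group on this nitrogen affects how much compound is needed, and that a sulfonyl group is not required there for a measurable effect, since compound 3, which has acetyl instead, still gives a number in this assay. The change removes a group of six heavy atoms, including the sulfur, and adds one of three, but no measurement here shows why the number moves.

As far as these compounds go, this single step cannot separate the loss of the sulfur from the change in group size, so it remains unknown which difference between isopropylsulfonyl and acetyl matters. Also open, from the compounds shown here alone, is how a methylsulfonyl group, a benzoyl group or a free amine at this same nitrogen would compare with acetyl, and whether a longer chain on the acetyl carbonyl would push the number up or down.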